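A few compounds are considered here, and "the series" means these few. Any claim that something is new, unique, unknown or untested is made for them only; others in the source may bear on it.

Compound 3 `C[C@H]1[C@H](NCc2ccc(C(C)(C)C)s2)C[C@H]2C[C@@H]1C2(C)C` stands lowest of the three numbers in an ADME assay on MDCK cells (Canis lupus familiaris) for cytotoxicity, read by microscopy, with a stated time of 48 h (a higher number here means that more compound is tolerated, a lower number that less compound is tolerated), at 780 nM. Compound 1 `C[C@H]1[C@H](NCc2ccc(Cl)s2)C[C@H]2C[C@@H]1C2(C)C` gives 25000 nM and compound 2 `C[C@H]1[C@H](NCc2cccs2)C[C@H]2C[C@@H]1C2(C)C` gives 25000 nM. Among the compounds with values here, the steps of a 32-fold lower number from compound 1 to compound 3 (1.51 log units; beyond the scatter) and a 32-fold lower number from compound 2 to compound 3 (1.51 log units; beyond the scatter) both mark the tert-butyl as the one change with a large effect, while no change at the digits printed from compound 1 to compound 2 (within the scatter) shows none. Compound 4 `C[C@H]1[C@H](NCc2ccc(-c3ccc(Br)s3)s2)C[C@H]2C[C@@H]1C2(C)C` carries 5-bromothiophen-2-yl in place of tert-butyl on an aromatic carbon. Within the data shown here, no measured step swaps one large group for another on this carbon, so the two large steps only suggest that a large group there goes with a low number. Compound 4 is therefore expected to stay near that level, with a 1.9-fold higher number from compound 3 to compound 4 (0.28 log units; within the scatter) modest and upward if anything. The estimate for compound 4 is 1500 nM, range 400 nM to 8000 nM.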

Compound 4, minimum cytotoxic concentration: 780 nM
Estimate against measurement, compound 4: 1.9-fold (0.28 log units) above; the measured number falls inside the stated range.
By their numbers in this assay, from the lowest: compounds 3 and 4 (each within the scatter of the next); then compounds 1 and 2 (each within the scatter of the next).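

In this assay the exchange of tert-butyl for 5-bromothiophen-2-yl gives no change at the digits printed from compound 3 to compound 4 (within the scatter) and so places two quite different groups on this carbon at one level. Measured against hydrogen and chloro, the new group shows a 32-fold lower number from compound 2 to compound 4 (1.51 log units; beyond the scatter) and a 32-fold lower number from compound 1 to compound 4 (1.51 log units; beyond the scatter) so that the low number is not tied to tert-butyl alone. No measurement shown offers a cause for this result.

Going by these compounds, whether a methyl or a phenyl on this carbon would group with hydrogen and chloro or with tert-butyl and 5-bromothiophen-2-yl stays open. So does the effect of a carboxylic acid or an amine there.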